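The source may hold more compounds than are shown below. What is called first, only, known or untested is meant among the compounds shown, and "the series" means these compounds.

Measured so far:
- compound 1, `CC(C)=CCc1cc(C(=O)Nc2cc3ccc(OCC4CCCN(C)C4)c(C)c3oc2=O)ccc1O`: 2640 nM
- compound 2, `CC(C)=CCc1cc(C(=O)Nc2cc3ccc(OCCCN4CCCC4)c(C)c3oc2=O)ccc1O`: 990 nM

In a functional assay on MCF7 cells (Homo sapiens) for antiproliferative activity (on this read-out higher numbers stand for weaker inhibition and lower numbers for stronger inhibition), compound 1 gives the highest of the two numbers; its nearest neighbour is compound 2, reached by a 2.7-fold lower number from compound 1 to compound 2 (0.43 log units; beyond the scatter). Compound 3, `CC(C)=CCc1cc(C(=O)Nc2cc3ccc(OCCCN(C)c4ccccc4)c(C)c3oc2=O)ccc1O`, is not yet measured. It differs from compound 1 as follows: 2-(methyl(phenyl)amino)ethyl in place of 1-methylpiperidin-3-yl on a saturated chain carbon bound to an oxygen on an aromatic ring. Within the data shown here, the only measured step at this place is a 2.7-fold lower number from compound 1 to compound 2 (0.43 log units; beyond the scatter), which replaced the same leaving group with another group and gave a modest change. That step concerns a different entering group, so it bears on the change to compound 3 only loosely, and nothing measured tells how the 2-(methyl(phenyl)amino)ethyl group itself behaves. A step of modest size, in either direction, or none beyond the scatter, is therefore expected. Compound 3 is estimated at 2500 nM, with a range from 700 nM to 9000 nM, which would mean an expected step of a 1.1-fold lower number from compound 1 to compound 3 (0.02 log units; within the scatter).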

Compound 3, half-maximal inhibitory concentration: > 50000 nM
Compound 3: no number, only a limit (the forecaster's own chance of this, stated with the estimate: 10%); middle value at least 20-fold (1.30 log units) from the limit.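

The compound 3 result is a limit of the assay, not a number: the limit of > 50000 nM in this assay, at which 1 of the 3 values shown sits.

Changes at this place are therefore not confined to the modest difference seen before: the step is an at least 18-fold higher number from compound 1 to compound 3 (1.27 log units; beyond the scatter), and on the same chain, changing only the amine gives an at least 50-fold higher number from compound 2 to compound 3 (1.70 log units; beyond the scatter). Among the three compounds, only compound 3, with methyl(phenyl)amino at the end of the chain, reaches the limit, so the group attached through this oxygen can decide whether this assay gives a measurable number at all.

Open, going by these compounds, is whether the phenyl ring on the nitrogen goes with this loss or the open-chain amine does; a dimethylamino group or a piperidin-1-yl group on the same chain would bear on that. Also open, on these data alone, is how far compound 3 really lies beyond its limit.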